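The source may report more compounds than this note shows. Statements on the series, on what has been measured and on what is new or still open speak of the compounds shown alone.

Measured so far:
- compound 1 `N#Cc1ncn(-c2ccc(F)cc2)c1/N=C/c1ccc([N+](=O)[O-])cc1`: 13400 nM
- compound 2 `N#Cc1ncn(-c2ccc(F)cc2)c1/N=C/c1ccc(O)cc1`: 16300 nM

In a functional assay on MDA-MB-231 cells (Homo sapiens) for antiproliferative activity, read by MTT assay, with a stated time of 48 h (on this read-out higher numbers stand for weaker inhibition and lower numbers for stronger inhibition), compound 1 has the lowest of the two numbers; its nearest neighbour is compound 2, with a 1.2-fold higher number from compound 1 to compound 2 (0.09 log units; within the scatter). Compound 3 `N#Cc1ncn(Cc2ccc(F)cc2)c1/N=C/c1ccc([N+](=O)[O-])cc1` differs from compound 1 by 4-fluorobenzyl in place of 4-fluorophenyl on an aromatic nitrogen. Among the compounds with values here, the one measured step concerns a different place on the core and does not bear on this change; no measured step bears on it. The expectation for compound 3 is therefore no step beyond the scatter, no change at the digits printed from compound 1 to compound 3 (within the scatter), with wide uncertainty. Compound 3 is estimated at 13400 nM, range 4500 nM to 40000 nM.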

Compound 3, half-maximal inhibitory concentration: 3440 nM
For compound 3 the middle estimate is 3.9-fold (0.59 log units) above the measured one; measured number below the stated range.
By their numbers in this assay, from the lowest: compound 3; then compounds 1 and 2 (each within the scatter of the next).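

Within the data shown here, the substituent on the aromatic nitrogen is the first place where a change moves the number beyond the scatter: in this assay, 4-fluorobenzyl in place of 4-fluorophenyl gives a 3.9-fold lower number from compound 1 to compound 3 (0.59 log units; beyond the scatter). The step between compound 1 and compound 2 did not show this, as it concerned a different place on the shared core. Nothing available here accounts for the step.

Still open, on these data alone, is whether the step holds with hydroxy in place of nitro, as in compound 2. As far as these compounds go, how a longer chain, such as 2-(4-fluorophenyl)ethyl, or an unsubstituted benzyl would read at this nitrogen also remains open.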